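Chain extension from compound 2 to compound 4

The source may hold more compounds than are shown below. What is called first, only, known or untested is meant among the compounds shown, and "the series" means these compounds.

Measured so far in a functional assay on A549 cells (Homo sapiens) for cytotoxicity, read by MTT assay, with a stated time of 48 h; on this read-out lower numbers stand for stronger inhibition and higher numbers for weaker inhibition:
- compound 1 `CCOC(=O)CSc1nnc(C)n1N1C(=O)c2ccccc2C1=O`: > 200000 nM, a limit of the assay.
- compound 2 `C#CCSc1nnc(C)n1N1C(=O)c2ccccc2C1=O`: > 200000 nM, again only a limit.
- compound 3 `CSc1nnc(C)n1N1C(=O)c2ccccc2C1=O`: > 200000 nM, also a limit.

Compound 2 thus stands at the limit together with the two other values shown (the limit of > 200000 nM in this assay, at which 3 of the 3 values shown sit). The steps a step that the two limits leave unreadable from compound 1 to compound 2, a step that the two limits leave unreadable from compound 1 to compound 3 and a step that the two limits leave unreadable from compound 2 to compound 3 all alter the group on a saturated chain carbon bound to a sulfur, and none is readable in size. For the measured compounds named here, compound 4 `C#CCSc1nnc(CCC)n1N1C(=O)c2ccccc2C1=O` differs from compound 2 by ethyl in place of hydrogen on a saturated chain carbon bound to an aromatic carbon, a place none of the measured steps touches, so no measured step bears directly on it. With every value at the limit, compound 4 is expected to stay near it, the step that the limit leaves unreadable from compound 2 to compound 4 in this assay expected not to exceed the scatter. The estimate for compound 4 is 300000 nM (100000 nM to 1000000 nM).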

Compound 4, half-maximal inhibitory concentration: > 200000 nM
Compound 4 ended at the assay's limit (the forecaster's own chance of this, stated with the estimate: 80%); the middle value is on the limit's open side.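

Compound 2 and compound 4 both stand at a limit, so no step between them can be read: the limit of > 200000 nM in this assay, at which 4 of the 4 values shown sit.

The compounds shown leave open how far any of these changes on the shared core moves the read-out.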